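Phenyl for cyclohexyl at the weak end of the series

The source may hold more compounds than are shown below. What is called first, only, known or untested is meant among the compounds shown, and "the series" means these compounds.

Within the data shown here, in a functional assay on A549 cells (Homo sapiens) for antiproliferative activity, read by MTT assay, with a stated time of 72 h (a lower number here means a stronger inhibitor, a higher number a weaker inhibitor), compound 1 `O=C1COc2ccc(-c3cnc(Cl)c(NS(=O)(=O)c4ccc(F)cc4)c3)cc2N1C1CCCCC1` gives 37900 nM, the only actual number so far. Compound 2 `O=C1COc2ccc(-c3cccc(NS(=O)(=O)c4ccc(F)cc4)c3)cc2N1c1ccccc1` is reported only as a limit, > 40000 nM. Compound 1 therefore stands as a very weak inhibitor, with no stronger reference available in the series.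

Compound 3 `O=C1COc2ccc(-c3cnc(Cl)c(NS(=O)(=O)c4ccc(F)cc4)c3)cc2N1c1ccccc1` keeps the core of compound 1 and changes one group, phenyl in place of cyclohexyl on an amide-type nitrogen in a ring. Among the measured compounds shown here, no measured pair isolates this change, so the expectation remains cautious. In this assay the step of a 1.7-fold lower number from compound 1 to compound 3 (0.24 log units; within the scatter) is expected to be small, towards a lower number, and it may not clearly exceed the usual scatter. A result reported only as a limit would also be unsurprising. Compound 3 is estimated at 22000 nM, with an expected range of 6000 nM to 40000 nM.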

Compound 3, half-maximal inhibitory concentration: 14700 nM
For compound 3 the middle estimate is 1.5-fold (0.18 log units) above the measured one; the measured number falls inside the stated range.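

In this assay, among these compounds, phenyl in place of cyclohexyl on the amide-type nitrogen gives a 2.6-fold lower number from compound 1 to compound 3 (0.41 log units; beyond the scatter), the first step that can be read. This position therefore responds to a change from a non-aromatic to an aromatic six-membered ring of carbon, with the heavy-atom count unchanged and no hydrogen-bond donor or acceptor added, although compound 3 at 14700 nM still sits at the weak end. Compound 2 is a limit of the assay and not a number, so it enters no step: the limit of > 40000 nM in this assay, at which 1 of the 3 values shown sits.

A single step at a single position gives no pattern. As far as these compounds go, whether a methoxy-substituted phenyl, a pyridine ring or a short chain ending in an amine on this nitrogen would move the number further remains open, as does whether the phenyl step carries over to other cores.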